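The source may hold more compounds than are shown below. What is called first, only, known or untested is meant among the compounds shown, and "the series" means these compounds.

Measured compounds in an ADME assay on Caco-2 cells (Homo sapiens) for permeability, in the apical to basolateral direction; on this read-out lower numbers stand for lower permeability and higher numbers for higher permeability:
- compound 1 `Cn1cnc(S(=O)(=O)N2CCC(CN(C3Cc4cc(C#N)ccc4N(Cc4cncn4C)C3)S(=O)(=O)c3ccccn3)CC2)c1`: 0.1 10^-6 cm/s
- compound 2 `Cc1noc(C)c1CN(C1Cc2cc(C#N)ccc2N(Cc2cncn2C)C1)S(=O)(=O)c1ccccn1`: 8 10^-6 cm/s
- compound 3 `Cn1cncc1CN1CC(N(Cc2cccc(-n3cccc3)c2)S(=O)(=O)c2ccccn2)Cc2cc(C#N)ccc21`: 2.3 10^-6 cm/s

Compound 1 gives the lowest number of the three in this assay. Compound 3 is nearest to it and compound 2 is furthest; both gaps lie beyond the scatter.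

The step under study leads to compound 4 `Cn1cncc1CN1CC(N(CC2CCN(C(=O)c3ccccc3)CC2)S(=O)(=O)c2ccccn2)Cc2cc(C#N)ccc21`. Relative to compound 1 the change is benzoyl in place of (1-methyl-1H-imidazol-4-yl)sulfonyl on an amine nitrogen in a ring.

Within the data shown here, the only measured step, a 3.5-fold lower number from compound 2 to compound 3 (0.54 log units; beyond the scatter), concerns a group on a saturated chain carbon bound to a sulfonamide nitrogen, a different place from the amine nitrogen in a ring changed here, and compounds 2 and 3 carry no group at that ring nitrogen at all. It therefore gives no direct guide to the size or direction of the step from compound 1 to compound 4. What can be said is that compound 1 stands far below compounds 2 and 3, so room upward is large. On that basis a moderate upward step is expected, a 10-fold higher number from compound 1 to compound 4 (1.00 log units; beyond the scatter), with wide uncertainty; compound 4 is estimated at 1 10^-6 cm/s, ranging from 0.2 10^-6 cm/s to 5 10^-6 cm/s.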

Compound 4, apparent permeability: 0.5 10^-6 cm/s
Beside the measured number, compound 4's estimate is 2.0-fold (0.30 log units) above it, within the range that was stated.
By their numbers in this assay, from the lowest: compound 1; then compound 4; then compound 3; then compound 2.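

In this assay, among these compounds, the amine nitrogen in a ring is a place where the attached group moves the read-out: benzoyl in place of (1-methyl-1H-imidazol-4-yl)sulfonyl gives a 5.0-fold higher number from compound 1 to compound 4 (0.70 log units; beyond the scatter), the first reading at this position, since compounds 2 and 3 carry no group at that nitrogen. The change is a bundled one, with a sulfonyl exchanged for a carbonyl and a five-membered aromatic ring with 2 hetero atoms exchanged for a six-membered aromatic ring of carbon only, and the entering group also has fewer hydrogen-bond acceptors, so a single step cannot assign the gain to any one of these differences. No measurement available here links the step to a property of either group.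

Still open, as far as these compounds go, is how far each part contributes: benzenesulfonyl on the same nitrogen would separate the linking group from the ring, while a 1-methyl-1H-imidazole-4-carbonyl group would test the reverse exchange. Acetyl, or a plain hydrogen on the ring nitrogen, would show whether an aromatic ring is needed at this position at all.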